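Compound 4: a bromine-bearing group replaces the pyridin-2-yl group

The compounds below may be only part of what the source reports. "The series", "measured", "known", "first", "only" and "open" are said of these compounds alone.

In a functional assay on HeLa cells (Homo sapiens) for inhibition, read by MTT assay, with a stated time of 48 h (a lower number here means a stronger inhibitor, a higher number a weaker inhibitor), compound 3 `CCOC(=O)C1=C(N/C=N/c2ccccn2)Nc2[nH]nc(C)c2C1c1ccc(N(C)C)cc1` gives 29200 nM, within the scatter of compound 1 `CCOC(=O)C1=C(N/C=N/c2nnc(S(N)(=O)=O)s2)Nc2[nH]nc(C)c2C1c1ccc(N(C)C)cc1` at 26300 nM, as a 1.1-fold higher number from compound 1 to compound 3 (0.05 log units; within the scatter) shows. Compound 2 `CCOC(=O)C1=C(N/N=C(/Br)c2ccccc2)Nc2[nH]nc(C)c2C1c1ccc(N(C)C)cc1` stands apart at 75700 nM, with a 2.9-fold higher number from compound 1 to compound 2 (0.46 log units; beyond the scatter). Compound 4 `CCOC(=O)C1=C(N/N=C(/C(=O)Br)c2ccc(Cl)cc2)Nc2[nH]nc(C)c2C1c1ccc(N(C)C)cc1` carries a group of 12 heavy atoms (8 carbon, 1 nitrogen, 1 oxygen, 1 chlorine, 1 bromine; one six-membered aromatic ring of carbon only) in place of a group of 8 heavy atoms (6 carbon, 2 nitrogen; one six-membered aromatic ring with 1 hetero atom), on an amine nitrogen. Like compound 2, it holds bromine and a six-membered aromatic ring of carbon only in this group, so compound 2 is the closer guide. The step that bears most directly is a 2.6-fold lower number from compound 2 to compound 3 (0.41 log units; beyond the scatter), and a modest rise in the reverse direction is therefore expected. The expected step is a 2.1-fold higher number from compound 3 to compound 4 (0.31 log units; beyond the scatter). The estimate for compound 4 is 60000 nM, with an expected range from 28000 nM to 130000 nM.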

Compound 4, half-maximal inhibitory concentration: 49300 nM
The estimate for compound 4 lay 1.2-fold (0.09 log units) above the measured number, within the range that was stated.
By their numbers in this assay, from the lowest: compounds 1, 3, 4 and 2 (each within the scatter of the next, the first and the last beyond it).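

In this assay, the group of 12 heavy atoms on the amine nitrogen cannot be told apart from the pyridin-2-yl group (a 1.7-fold higher number from compound 3 to compound 4 (0.23 log units; within the scatter)). It also cannot be told apart from the smaller bromine-bearing group of compound 2 (a 1.5-fold lower number from compound 2 to compound 4 (0.19 log units; within the scatter)) or the 5-sulfamoyl-1,3,4-thiadiazol-2-yl-bearing group of compound 1 (a 1.9-fold higher number from compound 1 to compound 4 (0.27 log units; within the scatter)). Bromine and a carbon-only aromatic ring therefore do not reproduce the clear separation between compound 1 and compound 2. No available evidence explains these results. As far as these compounds go, whether an amine or a carboxylic acid at this position would move the number beyond the scatter remains open.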